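The source may hold more compounds than are shown below. What is called first, only, known or untested is meant among the compounds shown, and "the series" means these compounds.

Compound 2, `Cc1ccccc1-c1ccc(-c2nnc(N(C)Cc3ccc4nccn4c3)o2)cc1`, stands highest of the two numbers recorded in a physicochemical assay for lipophilicity, at pH 7.4; a higher number here means a more lipophilic compound, a lower number a more polar compound: compound 2 gives 4.7. Its nearest neighbour is compound 1, `CN(Cc1ccc2nccn2c1)c1nnc(-c2ccc(-c3ccccc3C#N)cc2)o1`, which in this assay gives 3.6. Among the compounds with values here, the only step so far, a number 1.10 log units higher from compound 1 to compound 2 (beyond the scatter), is methyl in place of cyano on an aromatic carbon.

Compound 3, `Cc1nn(C)c(C)c1-c1ccc(-c2nnc(N(C)Cc3ccc4nccn4c3)o2)cc1`, has not yet been measured in this assay. Its change from compound 2 is 1,3,5-trimethyl-1H-pyrazol-4-yl in place of 2-methylphenyl on an aromatic carbon: the 2-methylphenyl leaves and a 1,3,5-trimethyl-1H-pyrazol-4-yl enters at the same place, on an aromatic carbon para to a large group, bringing two hydrogen-bond acceptors where there were none. Within the data shown here, no measured step covers an exchange of this kind, so the step from compound 1 to compound 2 gives no direct guide, and the expectation rests on the counted difference alone. The entering ring carries two hydrogen-bond acceptors in place of a ring of carbon only. On that basis a drop beyond the scatter is expected. For compound 3 the estimated step is a number 1.10 log units lower from compound 2 to compound 3 (beyond the scatter), and the expected value in this assay is 3.6, within a range from 3 to 4.2.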

Compound 3, distribution coefficient: 3.1
Compound 3: middle estimate off by 0.50 log units, on the high side; low and high end bracket the measured number.
By their numbers in this assay, from the lowest: compound 3; then compound 1; then compound 2.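

At this position, on an aromatic carbon para to a large group, this assay now follows an exchange of the whole ring and not only of a substituent on it: 1,3,5-trimethyl-1H-pyrazol-4-yl in place of 2-methylphenyl gives a number 1.60 log units lower from compound 2 to compound 3 (beyond the scatter). That step is larger than the methyl and cyano exchange seen earlier, even though the entering group has 8 heavy atoms against 7 for the one that leaves. The same group in place of 2-cyanophenyl gives a number 0.50 log units lower from compound 1 to compound 3 (beyond the scatter), so the trimethylpyrazolyl compound reads lowest of the three, and the nitrile-bearing phenyl ring no longer marks the low end at this place.

The compounds shown do not separate the two ring nitrogens from the three methyl groups, so it remains open how an unsubstituted pyrazole, a pyridine or an aminomethyl group would read here in this assay. No measurement shown explains the size of these steps or the order of the three compounds.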